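Swapping the head group on a shared amide nitrogen

A few compounds are considered here, and "the series" means these few. Any claim that something is new, unique, unknown or untested is made for them only; others in the source may bear on it.

Measured compounds:
- compound 1, `O=C(NO)c1ccc(N(Cc2ccc(C3CCCC3)cc2)C(=O)[C@H]2CCN2S(=O)(=O)c2c(F)c(F)c(F)c(F)c2F)cc1`, 7200 nM
- compound 2, `CONC(=O)c1ccc(N(Cc2ccc(C3CCCCC3)cn2)C(=O)[C@H]2CCN2S(=O)(=O)c2c(F)c(F)c(F)c(F)c2F)cc1O`, "not determined" (no result reported)
- compound 3, `O=C(NO)c1ccc(N(Cc2ccc(C3CCCC3)cn2)C(=O)[C@H]2CCN2S(=O)(=O)c2c(F)c(F)c(F)c(F)c2F)c(F)c1`, "not determined" (no result reported)

Three compounds share a core built around an amide-type nitrogen that carries a carbonyl carbon and a saturated chain carbon. Only compound 1 has a number in a functional assay on MCF7 cells (Homo sapiens) for antiproliferative activity, with a stated time of 72 h (a lower number here means that less compound is needed, a higher number that more compound is needed for the effect), and compound 1 gives 7200 nM. Compound 2 stands without a single number in this assay; the same holds for one further entry, compound 3, so neither of them can be placed on the scale.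

The step of interest leads from compound 2 to the unmeasured compound 4, `Cn1ccc2cc(N(Cc3ccc(C4CCCCC4)cn3)C(=O)[C@H]3CCN3S(=O)(=O)c3c(F)c(F)c(F)c(F)c3F)ccc2c1=O`. The change is a group of 12 heavy atoms (10 carbon, 1 nitrogen, 1 oxygen; one six-membered aromatic ring of carbon only, one six-membered aromatic ring with 1 hetero atom) in place of a group of 12 heavy atoms (8 carbon, 1 nitrogen, 3 oxygen; one six-membered aromatic ring of carbon only), on an amide-type nitrogen. A group with two hydrogen-bond donors and three acceptors leaves, and a group with no donors and two acceptors enters, on an amide-type nitrogen.

Within the data shown here, no measured step between any two compounds exists here, so the size and direction of this change cannot be read from data. Among the measured compounds shown here, the only anchor is compound 1 in this assay, which sits at a weak level. Compound 4 is therefore expected to land near 6000 nM, with a wide range from 1000 nM to 40000 nM, and a fair chance that only a limit is reported.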

Compound 4, half-maximal effective concentration: 2800 nM
The estimate for compound 4 lay 2.1-fold (0.33 log units) above the measured number; low and high end bracket the measured number.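

In this assay, among these compounds, compound 4 gives 2800 nM but compound 2 has no single number there, so no step from compound 2 to compound 4 can be read. The compounds shown leave open how the change of head group on the amide-type nitrogen shifts antiproliferative activity. No evidence bears on this result.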